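Bromo in Place of Hydrogen on Two Related Cores

The compounds below may be only part of what the source reports. "The series", "measured", "known", "first", "only" and "open" are said of these compounds alone.

Compound 2 `COCCOCn1cc(C#N)c2c(N)ncnc21`, compound 1 `COCCOCn1c(Br)c(C#N)c2c(N)ncnc21` and compound 3 `CCOCn1cc(C#N)c2c(N)ncnc21` were tested in a functional assay on KB cells (Homo sapiens) for inhibition; on this read-out higher numbers stand for weaker inhibition and lower numbers for stronger inhibition. In this assay compound 2 reaches only the limit of > 100000 nM. Compound 1 likewise gives the limit > 100000 nM. Compound 3 too gives the limit > 100000 nM. Compound 1 carries bromo in place of hydrogen on an aromatic carbon, and a step that the two limits leave unreadable from compound 2 to compound 1. The cores of compound 2 and compound 3 differ by hydrogen in place of methoxy on a saturated chain carbon, two bonds along the chain from an oxygen on a saturated carbon, and a step that the two limits leave unreadable from compound 2 to compound 3. All three values sit at the limit of > 100000 nM in this assay, at which 3 of the 3 values shown sit. Compound 4 `CCOCn1c(Br)c(C#N)c2c(N)ncnc21`, not yet measured, carries the same kind of change as compound 1: bromo in place of hydrogen on an aromatic carbon, the ring atom here bearing an ethoxymethyl group rather than a (2-methoxyethoxy)methyl group. Beside a step that the two limits leave unreadable from compound 2 to compound 1, the step that the limit leaves unreadable from compound 3 to compound 4 is expected to stay unreadable too, because compound 3 sits at the limit of > 100000 nM in this assay, at which 3 of the 3 values shown sit. Compound 4 is estimated at 200000 nM in this assay.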

Compound 4, half-maximal inhibitory concentration: > 100000 nM
Compound 4 ended at the assay's limit; the forecaster's own chance of this, stated with the estimate: 90%; the middle value does not contradict the limit.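

No step can be read between compound 1, compound 2, compound 3 and compound 4, as all four stop at one assay limit: the limit of > 100000 nM in this assay, at which 4 of the 4 values shown sit. The compounds shown leave open whether bromo in place of hydrogen changes inhibition at all.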